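The source may hold more compounds than are shown below. What is called first, only, known or untested is meant among the compounds shown, and "the series" means these compounds.

Measured compounds:
compound 1, `CCOC(=O)C1=C(Nc2ccccc2)S/C(=C\c2cccc(C(=O)O)c2)C1=O`: 50.6%
compound 2, `CCOC(=O)C1=C(Nc2ccc(CC)cc2)S/C(=C\c2ccc[nH]2)C1=O`: < 10%, a limit of the assay, not a number

Going by the values given here, in a functional assay on JAR cells (Homo sapiens) for inhibition, read by MTT assay, with a stated time of 72 h, tested at 10 uM (a higher number here means more inhibition at the concentration tested (going by the name of the read-out), a lower number less inhibition), compound 1 gives 50.6%, the only plain number among the two values. Compound 2 sits at the limit of < 10% in this assay, at which 1 of the 2 values shown sits, which is a limit of the assay and not a number. Among the compounds with values here, no pair of measured compounds differing in a single place is available, so no measured step sets a scale. Compound 3, `CCOC(=O)C1=C(Nc2ccccc2)S/C(=C\c2cc3cnccc3[nH]2)C1=O`, differs from compound 1 by a group of 9 heavy atoms (7 carbon, 2 nitrogen; one five-membered aromatic ring with 1 hetero atom, one six-membered aromatic ring with 1 hetero atom) in place of a group of 9 heavy atoms (7 carbon, 2 oxygen; one six-membered aromatic ring of carbon only), on a double-bonded chain carbon bound to a double-bonded ring carbon. A downward step of moderate size, a number 15.6 percentage points lower from compound 1 to compound 3 (beyond the scatter), is expected. Compound 3 is estimated at 35%, within 10% to 62%.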

Compound 3, a percentage reported as inhibition, at one concentration (the size of the read-out at that concentration, not a potency): < 10%
Compound 3 gave a limit, no number; the forecaster's own chance of this, stated with the estimate: 25%; middle value at least 25 percentage points away from the limit.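

At the double-bonded chain carbon bound to a double-bonded ring carbon, the 3-carboxyphenyl group cannot be exchanged freely: in this assay, putting the two-ring group in its place brings a number at least 40.6 percentage points lower from compound 1 to compound 3 (beyond the scatter), even though both groups count 9 heavy atoms. Matching that count is therefore not enough to keep the inhibition. The value of compound 3 is a limit of the assay, not a number: the limit of < 10% in this assay, at which 2 of the 3 values shown sit.

Going by these compounds, what remains open is which part of the 3-carboxyphenyl group matters. A plain phenyl group, or a methyl ester or an amide in place of the carboxylic acid, would help to separate the role of the acid from that of the ring.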